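Chlorophenyl for Methylphenyl: Expected Tolerance of Compound 4

The compounds below may be only part of what the source reports. "The series", "measured", "known", "first", "only" and "open" are said of these compounds alone.

Three compounds built on a shared core have been examined in an ADME assay on GES1 cells (Homo sapiens) for cytotoxicity, read by MTT assay, with a stated time of 24 h; a higher number here means that more compound is tolerated, a lower number that less compound is tolerated. Compound 1 `O=c1[nH]cc(S(=O)(=O)Nc2ccccc2-c2cn(-c3ccc(F)cc3)nn2)c(=O)[nH]1` is recorded in this assay as "not toxic" (no number reported), with no number behind that entry. Compound 2 `Cc1ccc(-n2cc(-c3cccc(NS(=O)(=O)c4c[nH]c(=O)[nH]c4=O)c3)nn2)cc1` gives 15800 nM in this assay, and compound 3 `Cc1cccc(-n2cc(-c3ccc(NS(=O)(=O)c4c[nH]c(=O)[nH]c4=O)cc3)nn2)c1` gives 28300 nM. Compound 3 holds the highest of the two numbers reported, yet its nearest neighbour, compound 2, lies within the usual scatter of this assay, so the two cannot be separated on these data. Compound 4 `O=c1[nH]cc(S(=O)(=O)Nc2ccc(-c3cn(-c4ccc(Cl)cc4)nn3)cc2)c(=O)[nH]1` has not yet been measured. It differs from compound 3 by 4-chlorophenyl in place of 3-methylphenyl on an aromatic nitrogen. For the measured compounds named here, no measured pair differing in one place is available to calibrate such an exchange, so the expectation rests on the narrow spread seen so far. The step of a 1.1-fold lower number from compound 3 to compound 4 (0.05 log units; within the scatter) is expected to stay within the scatter, with no direction favoured. Compound 4 is estimated at 25000 nM in this assay, within a range from 10000 nM to 60000 nM.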

Compound 4, half-maximal cytotoxic concentration: 23300 nM
Beside the measured number, compound 4's estimate is 1.1-fold (0.03 log units) above it, and the stated range covers the measured number.
By their numbers in this assay, from the lowest: compounds 2, 4 and 3 (each within the scatter of the next).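

In this assay, for the compounds shown here, putting 4-chlorophenyl in place of 3-methylphenyl on the aromatic nitrogen gives a 1.2-fold lower number from compound 3 to compound 4 (0.08 log units; within the scatter) as the first step here between compounds that differ in one place. It shows that this exchange at this position cannot be told apart from the usual scatter, though both groups are a six-membered aromatic ring of carbon only, with no hydrogen-bond donors or acceptors, so the test is a narrow one. No evidence on the reason for this result is available.

The compounds shown leave open whether the position would accept something other than such a ring, for instance a longer chain, or a phenyl ring carrying an amine or a carboxylic acid. The step also combines a change of substituent with a change of its place on the ring, and a 3-chlorophenyl group would separate the two.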